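Chain methyl removal in a weakly cytotoxic lactone series

The source may report more compounds than this note shows. Statements on the series, on what has been measured and on what is new or still open speak of the compounds shown alone.

Three compounds carry values in a functional assay on A549 cells (Homo sapiens) for cytotoxicity, read by MTT assay, with a stated time of 72 h; a lower number here means a stronger inhibitor, a higher number a weaker inhibitor. Compound 1 `CC/C=C/[C@H]1C[C@](O)(CC)[C@@H]([C@]2(CC)OC(=O)C[C@@H]2O)[C@@H]1C` gives 40400 nM. For compound 2 `CCCCC(C)C/C(=C/[C@@]1(CC)OC(=O)C[C@@H]1O)CC` the assay returns only a limit, > 100000 nM. Compound 3 `CCCCC(CC)C[C@]1(CC)O[C@H]1[C@]1(CC)C=CC(=O)O1` also returns only a limit, > 100000 nM, so compound 3 stands at the limit of this assay rather than at a number, one of the two values sitting at the limit of > 100000 nM in this assay, at which 2 of the 3 values shown sit. Compound 4 `CCCCC(C)C[C@]1(CC)O[C@H]1[C@]1(CC)C=CC(=O)O1` is not yet measured; it differs from compound 3 by hydrogen in place of methyl on a saturated chain carbon, three bonds along the chain from a saturated ring carbon. Among the measured compounds shown here, no measured pair differs in a single place, so no step size is available for guidance. A change of this kind is expected to shift this assay little, if at all, beyond the scatter, with a limit again the likely outcome. Compound 4 is therefore expected to give 150000 nM, within 30000 nM to 600000 nM. This estimate means a step that the limit leaves unreadable from compound 3 to compound 4.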

Compound 4, half-maximal inhibitory concentration: > 100000 nM
Compound 4: only a limit was reported; the forecaster's own chance of this, stated with the estimate: 75%; the middle value does not contradict the limit.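

Compound 3 and compound 4 both return only a limit in this assay, so no step can be read between them: the limit of > 100000 nM in this assay, at which 3 of the 4 values shown sit.

The compounds shown leave open whether hydrogen in place of methyl on this chain carbon shifts cytotoxicity at all.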